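The compounds below may be only part of what the source reports. "The series", "measured", "known", "first", "only" and "open" are said of these compounds alone.

Compound 2 `CC1(OC(=O)N2CCC3(CC2)CC(CCCOc2ccc(S(C)(=O)=O)c(F)c2)C3)CC1` gives the lowest number of the three measured, with 13 nM in a functional assay on cells for agonist activity at Glucose-dependent insulinotropic receptor (Homo sapiens), read by HTRF and cAMP accumulation, with a stated time of 30 min; on this read-out higher numbers stand for an effect only at larger amounts of compound and lower numbers for an effect already at smaller amounts; compound 1 `CC(C)OC(=O)N1CCC2(CC1)CC(CCCOc1ccc(S(C)(=O)=O)cc1)C2` gives 78 nM in this assay, and compound 3 `CCc1cnc(N2CCC3(CC2)CC(CCCOc2ccc(S(C)(=O)=O)cc2F)C3)nc1` gives 225 nM. Compound 4 `CCc1cnc(N2CCC3(CC2)CC(CCCOc2ccc(S(C)(=O)=O)c(F)c2)C3)nc1` differs from compound 2 by a single change: 5-ethylpyrimidin-2-yl in place of ((1-methylcyclopropyl)oxy)carbonyl on an amine nitrogen in a ring. Within the data shown here, no measured pair isolates this change, and the only other compound carrying the 5-ethylpyrimidin-2-yl group, compound 3, also differs from compound 2 elsewhere, so its higher number cannot be assigned to the pyrimidine alone. The expected step of a 3.8-fold higher number from compound 2 to compound 4 (0.59 log units; beyond the scatter) is a moderate loss, beyond the scatter, towards a higher number. The estimate for compound 4 in this assay is 50 nM, within a range from 12 nM to 200 nM.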

Compound 4, half-maximal effective concentration: 123 nM
The estimate for compound 4 lay 2.5-fold (0.39 log units) below the measured number, within the range that was stated.
By their numbers in this assay, from the lowest: compound 2; then compounds 1, 4 and 3 (each within the scatter of the next, the first and the last beyond it).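

Among these compounds, for the first time, a single exchange on the amine nitrogen in the ring can be read alone: in this assay, 5-ethylpyrimidin-2-yl in place of ((1-methylcyclopropyl)oxy)carbonyl gives a 9.5-fold higher number from compound 2 to compound 4 (0.98 log units; beyond the scatter) with the rest of the structure unchanged. This step lies beyond the scatter, so the read-out depends on the group at this position, even though both groups count the same hydrogen-bond acceptors and no donors. From the compounds shown here alone, whether a tert-butoxycarbonyl group or a 5-methylpyrimidin-2-yl group on this nitrogen would give a lower or higher number remains open. Nothing measured here explains the step.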